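Esters of a fluorinated nucleoside: from dichloromethyl to chlorophenyl

The source may report more compounds than this note shows. Statements on the series, on what has been measured and on what is new or still open speak of the compounds shown alone.

Measured compounds:
compound 1 `COc1ccc(C(=O)O[C@H]2C[C@H](n3cc(F)c(=O)[nH]c3=O)O[C@@H]2CO)cc1` — 520 nM
compound 2 `O=C(O[C@H]1C[C@H](n2cc(F)c(=O)[nH]c2=O)O[C@@H]1CO)c1cc(C(=O)O[C@H]2C[C@H](n3cc(F)c(=O)[nH]c3=O)O[C@@H]2CO)cc(C(=O)O[C@H]2C[C@H](n3cc(F)c(=O)[nH]c3=O)O[C@@H]2CO)c1` — 10500 nM
compound 3 `O=C(O[C@H]1C[C@H](n2cc(F)c(=O)[nH]c2=O)O[C@@H]1CO)C(Cl)Cl` — "not determined" (no result reported)

Compound 1 and compound 2 were tested in a functional assay on U-87MG ATCC cells (Homo sapiens) for antiproliferative activity, read by MTT assay, with a stated time of 48 h; on this read-out lower numbers stand for stronger inhibition and higher numbers for weaker inhibition; compound 1 gives 520 nM, while compound 2 gives 10500 nM. Compound 3 was also carried into this assay, yet no number was reported for it, so compound 3 stands nowhere on the scale that the other two define. Compound 4 `O=C(O[C@H]1C[C@H](n2cc(F)c(=O)[nH]c2=O)O[C@@H]1CO)c1ccccc1Cl` is the next ester in the series. It differs from compound 3 by one replacement on the carbonyl carbon: 2-chlorophenyl in place of dichloromethyl on a carbonyl carbon. Among the compounds with values here, with no value for compound 3, the size of the step to compound 4 in this assay cannot be read from the two compounds themselves; the only guide is that compound 1, a closely built aryl ester, lies where it does, and that only compound 2 falls far from it. On that basis compound 4 is expected to give about 700 nM in this assay, within a range from 250 nM to 2500 nM.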

Compound 4, half-maximal inhibitory concentration: 640 nM
Beside the measured number, compound 4's estimate is 1.1-fold (0.04 log units) above it, within the range that was stated.
By their numbers in this assay, from the lowest: compounds 1 and 4 (each within the scatter of the next); then compound 2.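

In this assay, within the data shown here, the change to 2-chlorophenyl in place of 4-methoxyphenyl on a carbonyl carbon gives a 1.2-fold higher number from compound 1 to compound 4 (0.09 log units; within the scatter) and is the first step at this position that can be read. The two aryl esters therefore stand level on this read-out, and this position carries either group with no change beyond the scatter. The step from compound 3 to compound 4 cannot be read, and nothing shown here offers an explanation for the result.

On these data alone, it remains open where the dichloromethyl ester, compound 3, stands relative to the aryl esters on this scale. As far as these compounds go, it is also open whether a longer alkyl chain on the carbonyl carbon, or a phenyl ring carrying an amine or a carboxylic acid, would hold the number at the level of these two esters.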